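The compounds below may be only part of what the source reports. "The series", "measured", "known", "first", "only" and "open" are said of these compounds alone.

Of the compounds shown here, three built on one shared core have been tested in an ADME assay on HepG2 2.2.15 cells (Homo sapiens) for cytotoxicity; on this read-out higher numbers stand for lower toxicity in this test and lower numbers for higher toxicity in this test. Compound 1 `CCOC(=O)CCCNc1ncc(C(Oc2ccc3cc(Br)ccc3c2)c2ccc(Cl)cc2)s1` is recorded simply as "not toxic" (no number reported), without a figure. Compound 2 `O=C(Nc1ncc(C(Oc2ccc3cc(Br)ccc3c2)c2ccc(Cl)cc2)s1)c1ccc(F)cc1Br` reaches only a limit of the test, > 50000 nM, so no exact number is given for it either. Compound 3 `O=S(=O)(Nc1ncc(C(Oc2ccc3cc(Br)ccc3c2)c2ccc(Cl)cc2)s1)c1cccs1` is again recorded as "not toxic" (no number reported), once more without a number. Where compound 3 stands is therefore told in words rather than in numbers: none of the three results is a single figure, one of them sits at the limit of > 50000 nM in this assay, at which 1 of the 3 values shown sits, and the other two are verbal reports of no toxicity.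

Compound 4 `O=S(=O)(Nc1ncc(C(Oc2ccc3cc(Br)ccc3c2)c2ccc(Cl)cc2)s1)c1cccc2cccnc12` has not yet been measured. It differs from compound 3 in one place: quinolin-8-yl in place of thiophen-2-yl on a sulfonyl sulfur. Going by the values given here, no step between two measured compounds exists here, so the size of change to expect in this assay cannot be read from a measured pair. Since compound 3 is recorded as "not toxic" (no number reported), the expectation is that compound 4 stays in the same region, with no shift beyond the usual scatter. Compound 4 is expected to come out near 50000 nM, within 20000 nM to 100000 nM, and may again be reported only as a limit.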

Compound 4, half-maximal cytotoxic concentration: > 50000 nM
Compound 4: only a limit was reported; the forecaster's own chance of this, stated with the estimate: 70%; the middle value sits exactly at the limit.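

In this assay compound 4 gives only a limit, > 50000 nM. Compound 3 is recorded as not toxic without a number, so no step can be read from compound 3 to compound 4. The compounds shown leave open where any actual cytotoxic concentration lies, and whether changing the group on the sulfonyl sulfur affects it.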